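From a Branched Alkene Ether to a Cyclopentyl-Bearing Ether

A few compounds are considered here, and "the series" means these few. Any claim that something is new, unique, unknown or untested is made for them only; others in the source may bear on it.

Of the compounds shown here, two with a shared core have been tested in an assay on THP-1 cells for inhibition of nuclear factor NF-kappa-B complex (Homo sapiens), with stated times of 2 h and 16 h; a higher number here means a weaker inhibitor, a lower number a stronger inhibitor. Compound 1, `CC(C)=CCOc1cccc(O)c1C(=O)/C=C/c1ccc(O)cc1`, carries a (3-methylbut-2-en-1-yl)oxy chain on one aromatic ring and a hydroxyl on the other. In this assay compound 1 gives only a limit, > 30000 nM, so no number is known for it; it stands at the limit of > 30000 nM in this assay, at which 1 of the 2 values shown sits. Compound 2, `CC(C)(C)CCOc1cccc(O)c1C(=O)/C=C/c1ccc(S(N)(=O)=O)cc1`, differs from compound 1 in more than one place, with a longer saturated ether chain and a sulfonamide in place of the hydroxyl, and in this assay compound 2 gives 1200 nM. Those two differ in several places at once. Among the measured compounds shown here, their values show only that compound 2 is the stronger of the pair, not which change matters.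

Compound 3, `O=C(/C=C/c1ccc(O)cc1)c1c(O)cccc1OCCC1CCCC1`, keeps everything of compound 1 except the ether chain: cyclopentylmethyl in place of 2-methylprop-1-en-1-yl on a saturated chain carbon bound to an oxygen on an aromatic ring. The chain becomes saturated and carries a ring where the double bond was.

For the measured compounds named here, no measured step of this kind exists to lean on, so the change is expected to leave the weak inhibition largely as it is; the step of an at least 1.2-fold lower number from compound 1 to compound 3 (0.07 log units; that floor lies within the scatter) is expected to be small, possibly within the scatter. Compound 3 is therefore estimated at 25000 nM, with a range from 5000 nM to 100000 nM, and a real chance that this assay again reports only a limit.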

Compound 3, half-maximal inhibitory concentration: 18000 nM
For compound 3 the middle estimate is 1.4-fold (0.14 log units) above the measured one; the measured number falls inside the stated range.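

This is the only pair shown that differs in one place, so the effect of the ether chain can be read on its own for the first time: 2-cyclopentylethyl in place of 3-methylbut-2-en-1-yl, with the hydroxyl and the rest of the core unchanged, gives an at least 1.6-fold lower number from compound 1 to compound 3 (0.22 log units; that floor lies within the scatter) in this assay. With only the chain altered, compound 3 yields an actual number in this assay, although the floor of this step does not by itself establish a real gain. The true size of the step stays unknown because compound 1 has only a limit, and a limit is not a number: the limit of > 30000 nM in this assay, at which 1 of the 3 values shown sits.

Going by these compounds, it remains open whether a longer chain such as 2-cyclohexylethyl, or an amine at the end of the chain, would shift the value further. Also open, on these data alone, is how much the sulfonamide of compound 2 contributes by itself, since compound 2 differs from both other compounds in more than one place.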